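The compounds below may be only part of what the source reports. "The series", "measured", "known", "first", "only" and "open" are said of these compounds alone.

Compound 1 `Oc1cccc2c1CCCC2c1c[nH]cn1`: in an assay on isolated protein (Cricetulus griseus) for binding affinity to Alpha-1B adrenergic receptor (Mesocricetus auratus), read by radioligand binding (on this read-out lower numbers stand for stronger inhibition and higher numbers for weaker inhibition), compound 1 gives 145 nM.
Compound 2 `CS(=O)(=O)Nc1ccc(Cl)c2c1CCCC2c1c[nH]cn1`: compound 2 gives < 10000 nM, which is a limit of this assay, not a number.
Compound 3 `CS(=O)(=O)Nc1cccc2c1CCCCC2c1c[nH]cn1`: compound 3 gives 10000 nM.

Of the two numbers shown, compound 1 gives the lowest, and its nearest neighbour, compound 3, sits higher by a gap beyond the usual scatter of repeated measurements. Compound 4 `CN(c1cccc2c1CCCC2c1c[nH]cn1)S(C)(=O)=O` has not yet been measured in this assay. It differs from compound 1 in one place: methyl(methylsulfonyl)amino in place of hydroxy on an aromatic carbon. Within the data shown here, no measured pair shares this exact change, so its size is open. Weaker binding is expected, with a step of a 21-fold higher number from compound 1 to compound 4 (1.32 log units; beyond the scatter) toward higher numbers. Compound 4 is expected to give about 3000 nM, within 600 nM to 10000 nM.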

Compound 4, inhibition constant: < 10000 nM
Compound 4: only a limit was reported (the forecaster's own chance of this, stated with the estimate: 30%); the middle value is on the limit's open side.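

Compound 4 gives < 10000 nM, which is a limit and not a number, so the step from compound 1 to compound 4 cannot be read: the limit of < 10000 nM in this assay, at which 2 of the 4 values shown sit. The compounds shown leave open how far the number in this assay shifts when methyl(methylsulfonyl)amino takes the place of hydroxy.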